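Swapping a Nitrile for a Fluoropyrimidine in a Cytotoxicity Series

A few compounds are considered here, and "the series" means these few. Any claim that something is new, unique, unknown or untested is made for them only; others in the source may bear on it.

Compound 1 `N#CC1CC(=O)N(c2cnn3c2CN(C(=O)Nc2cc(F)c(F)c(F)c2)C(C2CC2)C3)C1`: > 200000 nM
Compound 2 `O=C1OC(c2ccccc2)CN1c1cnn2c1CN(C(=O)Nc1cc(F)c(F)c(F)c1)C(C1CC1)C2`: 7410 nM
Compound 3 `CC1(C)CC(=O)N(c2cnn3c2CN(C(=O)Nc2cc(F)c(F)c(F)c2)C(C2CC2)C3)C1`: 115000 nM

In a toxicity assay on HepG2 2.2.15 cells (Homo sapiens) for cytotoxicity, read by CellTiter-Glo (a higher number here means that more compound is tolerated, a lower number that less compound is tolerated), compound 1 gives > 200000 nM, a limit of the assay and not a number. Compound 1 thus sits at the limit of > 200000 nM in this assay, at which 1 of the 3 values shown sits.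

Compound 4 `O=C1CC(c2ncc(F)cn2)CN1c1cnn2c1CN(C(=O)Nc1cc(F)c(F)c(F)c1)C(C1CC1)C2` carries 5-fluoropyrimidin-2-yl in place of cyano on a saturated ring carbon.

Going by the values given here, two measured steps bear on this change. The step of an at least 26-fold lower number from compound 1 to compound 2 (1.43 log units; beyond the scatter) brings in a phenyl-bearing group and is large. The step of an at least 1.7-fold lower number from compound 1 to compound 3 (0.24 log units; that floor lies within the scatter) brings in no aromatic ring, and its floor lies within the scatter. Compound 4 also gains an aromatic ring, so a lower number is expected, by analogy with an at least 26-fold lower number from compound 1 to compound 2 (1.43 log units; beyond the scatter).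

The expected step is an at least 5.7-fold lower number from compound 1 to compound 4 (0.75 log units; beyond the scatter).

For compound 4 the estimate is 35000 nM, with an expected range of 9000 nM to 150000 nM.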

Compound 4, half-maximal cytotoxic concentration: 115000 nM
Compound 4: middle estimate off by 3.3-fold (0.52 log units), on the low side; the measured number falls inside the stated range.
By their numbers in this assay, from the lowest: compound 2; then compounds 3 and 4 (each within the scatter of the next). At a limit, above all of these: compound 1.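

In this assay, 5-fluoropyrimidin-2-yl in place of cyano on this saturated ring carbon gives an at least 1.7-fold lower number from compound 1 to compound 4 (0.24 log units; that floor lies within the scatter). Compound 1 stands at > 200000 nM, a limit of the assay and not a number, so the true size of this step cannot be read. An aromatic ring entering at this position therefore need not bring a step as large as an at least 26-fold lower number from compound 1 to compound 2 (1.43 log units; beyond the scatter).

The compounds shown leave open how an amine or a carboxylic acid on this ring carbon would fare in this assay. From the compounds shown here alone, whether an unsubstituted phenyl here would behave like 5-fluoropyrimidin-2-yl also stays open.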